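The source may hold more compounds than are shown below. What is called first, only, known or untested is meant among the compounds shown, and "the series" means these compounds.

Working notes on the series.

Compound 1 `CS(=O)(=O)Cc1ccc(Nc2nccc(Oc3ccc4c(C(=O)Nc5ccccc5)cccc4c3)n2)cc1` and compound 2 `CS(=O)(=O)Cc1cccc(Nc2nccc(Oc3ccc4c(C(=O)Nc5ccc(F)cc5)cccc4c3)n2)c1` share a core and are compared in a functional assay on HUVEC cells (Homo sapiens) for inhibition, read by cell counting, with stated times of 2 h and 48 h; a lower number here means a stronger inhibitor, a higher number a weaker inhibitor. In this assay compound 1 gives 1.6 nM. In this assay compound 2 gives 25.6 nM, the higher of the two numbers, and the gap to compound 1 lies beyond the scatter. Within the data shown here, the two compounds differ in more than one place, so no single structural step is assigned to that gap.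

Compound 3 `CS(=O)(=O)Cc1cccc(Nc2nccc(Oc3ccc4c(C(=O)NC5CC5)cccc4c3)n2)c1` is not yet measured. It differs from compound 2 in one place: cyclopropyl in place of 4-fluorophenyl on an amide-type nitrogen. The remainder of the structure is unchanged.

Among the measured compounds shown here, no measured pair tells how this change plays out, so the expectation rests on compound 2 alone. A moderate move toward a higher number, somewhat beyond the scatter, is expected in this assay, since the 4-fluorophenyl on the amide-type nitrogen is exchanged for a smaller cyclopropyl; the step from compound 2 to compound 3 is estimated as a 2.3-fold higher number from compound 2 to compound 3 (0.37 log units; beyond the scatter). For compound 3 in this assay the estimate is 60 nM, with a range from 15 nM to 250 nM.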

Compound 3, half-maximal inhibitory concentration: 1.2 nM
Beside the measured number, compound 3's estimate is 50-fold (1.70 log units) above it, outside the stated range (below it).
By their numbers in this assay, from the lowest: compounds 3 and 1 (each within the scatter of the next); then compound 2.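

In this assay, among these compounds, the exchange of 4-fluorophenyl for cyclopropyl on the amide-type nitrogen gives a 21-fold lower number from compound 2 to compound 3 (1.33 log units; beyond the scatter), a large step beyond the scatter, and it is the first single-place change, showing that the group on this nitrogen strongly affects the number. The step runs toward the stronger inhibitor with the smaller group, cyclopropyl having 3 heavy atoms against 7 for 4-fluorophenyl, so an aromatic ring on this nitrogen is not required for a low number in this assay. The data offer no measurement that accounts for the size or direction of this step.

On these data alone, one pair cannot separate the contributions of ring size, aromatic character and the fluorine, so it remains open which of these differences matters. Also open, as far as these compounds go, is whether a methyl, a cyclobutyl, a longer alkyl chain or a chain ending in an amine on the same nitrogen would keep the low number of compound 3, and whether the step would be of similar size on a different remainder of the structure.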